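Three Amine Substituents, One Potency: Testing a Bicyclic Ether

The source may hold more compounds than are shown below. What is called first, only, known or untested is meant among the compounds shown, and "the series" means these compounds.

Measured so far:
Compound 1, `O=C(Nc1ccnnc1)c1cc(N2CCCC2)ccc1OCc1ccccc1`: 20 nM
Compound 2, `CN1CCC(c2ccc(OCc3ccccc3)c(C(=O)Nc3ccnnc3)c2)CC1`: 20 nM
Compound 3, `O=C(Nc1ccnnc1)c1cc(N2CCC(CO)CC2)ccc1OCc1ccccc1`: 20 nM

The three compounds share one core and differ only in the amine attached to the aromatic carbon. In an assay on Sf9 cells for inhibition of Leucine-rich repeat serine/threonine-protein kinase 2 (Homo sapiens), read by TR-FRET, with stated times of 30 min and 2 h (a higher number here means a weaker inhibitor, a lower number a stronger inhibitor), compound 3 stands level with compounds 1 and 2; the step of no change at the digits printed from compound 1 to compound 3 (within the scatter) and the step of no change at the digits printed from compound 2 to compound 3 (within the scatter) both sit inside the scatter, as does no change at the digits printed from compound 1 to compound 2 (within the scatter).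

Compound 4, `O=C(Nc1ccnnc1)c1cc(N2C[C@H]3COC[C@H]3C2)ccc1OCc1ccccc1`, is not yet measured. It differs from compound 3 by a group of 8 heavy atoms (6 carbon, 1 nitrogen, 1 oxygen; 2 five-membered non-aromatic rings with 1 hetero atom each) in place of a group of 8 heavy atoms (6 carbon, 1 nitrogen, 1 oxygen; one six-membered non-aromatic ring with 1 hetero atom), on an aromatic carbon. Every measured step at this position, from a pyrrolidin-1-yl through a 1-methylpiperidin-4-yl to a 4-(hydroxymethyl)piperidin-1-yl, left this assay unchanged, so the same outcome is expected here, with no step beyond the scatter: no change at the digits printed from compound 3 to compound 4 (within the scatter). On that basis compound 4 is estimated to give 20 nM in this assay, expected to fall between 8 nM and 50 nM.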

Compound 4, half-maximal inhibitory concentration: 50.1 nM
Estimate against measurement, compound 4: 2.5-fold (0.40 log units) below; measured number outside the range, above it.
By their numbers in this assay, from the lowest: compounds 1, 2 and 3 (each within the scatter of the next); then compound 4.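

In this assay, the position para to the benzyloxy group proved not to be indifferent to the group it carries: exchanging the 4-(hydroxymethyl)piperidin-1-yl for the group with two five-membered non-aromatic rings gave a 2.5-fold higher number from compound 3 to compound 4 (0.40 log units; beyond the scatter), although both groups hold 8 heavy atoms. Among the compounds shown here, the same group also separates compound 4 from the two other amines, with a 2.5-fold higher number from compound 2 to compound 4 (0.40 log units; beyond the scatter) and a 2.5-fold higher number from compound 1 to compound 4 (0.40 log units; beyond the scatter), so these are the first steps at this position to lie beyond the scatter. Nothing in the available data explains the difference.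

The change swaps the ring system and also loses the hydrogen-bond donor, and these compounds cannot separate the two. On these data alone, whether a morpholin-4-yl group or a piperidine bearing a carboxylic acid would stand level with compounds 1, 2 and 3 or with compound 4 remains open.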